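From Cyclopropylpiperazine to Dimethylmorpholine on a Carbonyl Carbon

The source may hold more compounds than are shown below. What is called first, only, known or untested is meant among the compounds shown, and "the series" means these compounds.

Among the measured compounds shown here, only two compounds have been measured so far in an ADME assay on microsomes from liver (Rattus norvegicus) for metabolic stability, read by LC-MS, using NADPH, with a stated time of 60 min, tested at 0.1 uM; on this read-out lower numbers stand for a less stable compound and higher numbers for a more stable compound. Compound 1 `Fc1ccc(Nc2cc3[nH]c(Nc4ccc(N5CCNCC5)cn4)nc3cn2)cc1F` gives 73%. Compound 2 `O=C(c1ccnc(Nc2nc3cnc(Nc4ccc(F)c(C(F)(F)F)c4)cc3[nH]2)c1)N1CCN(C2CC2)CC1` gives 53%, the lower of the two numbers, and the gap between them lies beyond the usual scatter. These two compounds differ in more than one place, so their gap cannot be pinned on any single change.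

Compound 3 `C[C@@H]1CN(C(=O)c2ccnc(Nc3nc4cnc(Nc5ccc(F)c(C(F)(F)F)c5)cc4[nH]3)c2)C[C@H](C)O1` has not yet been measured. It carries 2,6-dimethylmorpholin-4-yl in place of the 4-cyclopropylpiperazin-1-yl of compound 2 on a carbonyl carbon: 2,6-dimethylmorpholin-4-yl in place of 4-cyclopropylpiperazin-1-yl on a carbonyl carbon. For the measured compounds named here, no measured pair shows this change, so the expectation in this assay is no step beyond the scatter, and it stays anchored on compound 2 at 53%. The estimated step is a number 2 percentage points higher from compound 2 to compound 3 (within the scatter). Compound 3 is expected to read 55%, with an estimated range of 35% to 75%.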

Compound 3, percent of the compound remaining: 65%
Estimate against measurement, compound 3: 10 percentage points below; the range from low to high includes it.
By their numbers in this assay, from the lowest: compound 2; then compounds 3 and 1 (each within the scatter of the next).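

In this assay, among the compounds shown here, the substituent on the carbonyl carbon turns out to matter: 2,6-dimethylmorpholin-4-yl in place of 4-cyclopropylpiperazin-1-yl gives a number 12 percentage points higher from compound 2 to compound 3 (beyond the scatter) and so provides the first change in this set that can be read at a single place. Compound 2 and compound 3 differ nowhere else, so this modest step belongs to the exchange as a whole. Nothing in the available data explains the step.

The exchange removes the cyclopropyl ring, replaces a ring nitrogen with oxygen and adds two methyl groups with defined stereocentres, and the compounds shown do not separate these parts. Plain morpholin-4-yl or 4-methylpiperazin-1-yl on the same carbonyl carbon would be needed to tell which part carries the step.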